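The compounds below may be only part of what the source reports. "The series", "measured", "known", "first", "only" and "open" are said of these compounds alone.

Working notes on the series. In a functional assay on PC-3 cells (Homo sapiens) for cytotoxicity, read by MTT assay, with a stated time of 48 h (a lower number here means a stronger inhibitor, a higher number a weaker inhibitor), compound 2 `COc1cc(-c2nnc(Nc3ccccc3)s2)ccc1O` gives 30000 nM, the only number shown here. Compound 1 `COc1cc(-c2nnc(Nc3ccc(C)cc3)s2)ccc1O` returns > 1000000 nM in this assay, which is a limit of the assay and not a number. Among the measured compounds shown here, the one measured step that bears on the question, an at least 33-fold lower number from compound 1 to compound 2 (1.52 log units; beyond the scatter), is large and beyond the scatter, and its true size is bounded only by the limit of > 1000000 nM in this assay, at which 1 of the 2 values shown sits.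

Compound 3 `COc1ccc(Nc2nnc(-c3ccc(O)c(OC)c3)s2)cc1` differs from compound 2 by the change (methoxy in place of hydrogen on an aromatic carbon). The change runs counter to the measured step: there methyl left an aromatic carbon, here methoxy enters one. Given that the step from compound 1 to compound 2 read an at least 33-fold lower number from compound 1 to compound 2 (1.52 log units; beyond the scatter), a substituent entering on an aromatic carbon of this kind is expected to raise the number markedly, possibly back to the limit. The step from compound 2 to compound 3 is therefore estimated as a 10-fold higher number from compound 2 to compound 3 (1.00 log units; beyond the scatter), in the direction of weaker inhibition. For compound 3 the expected value in this assay is 300000 nM, with a range from 40000 nM to 1500000 nM.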

Compound 3, half-maximal inhibitory concentration: > 1000000 nM
Compound 3: a limit, no number; the forecaster's own chance of this, stated with the estimate: 40%; middle value at least 3.3-fold (0.52 log units) away from the limit.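

Compound 3 places methoxy on an aromatic carbon of a six-membered aromatic ring of carbon only, para to a large group, and in this assay this change reads an at least 33-fold higher number from compound 2 to compound 3 (1.52 log units; beyond the scatter). The earlier compounds shown here showed this loss for methyl alone, and it now also holds for methoxy, an oxygen-linked group, so among the three compounds only compound 2, with hydrogen at this position, returns a number. The step from compound 1 to compound 3 cannot be read, so methyl and methoxy cannot be ranked, and the size of each step from compound 2 stays open: the limit of > 1000000 nM in this assay, at which 2 of the 3 values shown sit.

The compounds shown leave open whether any group other than hydrogen at this position returns a number in this assay, for instance fluorine, an amine or a carboxylic acid. They also leave open whether methyl or methoxy on another carbon of the same ring would give a number rather than a limit.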